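Methoxy to hydroxy on the pendant aryl, compound 4

This account rests on a few compounds, and the source may have more. Where it says the series, first, only, none or still open, it means among the compounds named here.

Going by the values given here, compound 3 `COc1cc(-c2nn(-c3cccc(NC(=O)Nc4ccc(Cl)c(C(F)(F)F)c4)c3)cc2-c2ccncc2)ccc1Cl` holds the lowest of the three numbers so far: in a functional assay on Malme-3M cells (Homo sapiens) for inhibition, read by sulforhodamine B assay, with a stated time of 48 h (a higher number here means a weaker inhibitor of growth, a lower number a stronger inhibitor of growth), compound 3 gives 838 nM. Compound 2 `O=C(Nc1cccc(-n2cc(-c3ccncc3)c(-c3ccc(Cl)c(O)c3)n2)c1)Nc1ccc(Cl)c(Cl)c1` sits nearest, giving 1190 nM in this assay, a gap within the scatter; compound 1 `O=C(Nc1cccc(-n2cc(-c3ccncc3)c(-c3ccc(Cl)c(O)c3)n2)c1)Nc1cccc(C(F)(F)F)c1` is furthest, giving 1810 nM, a gap beyond the scatter.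

Compound 4 `O=C(Nc1cccc(-n2cc(-c3ccncc3)c(-c3ccc(Cl)c(O)c3)n2)c1)Nc1ccc(Cl)c(C(F)(F)F)c1` differs from compound 3 by one change, (hydrogen in place of methyl on an oxygen on an aromatic ring), that is, hydrogen in place of methyl on an oxygen on an aromatic ring, methoxy to hydroxy. Among the compounds with values here, the only step measured so far, a 1.5-fold lower number from compound 1 to compound 2 (0.18 log units; within the scatter), concerns the aryl on the urea nitrogen and says nothing about this oxygen. Compounds 1 and 2 both carry the hydroxy group and give the two higher numbers; compound 3 with methoxy gives the lowest, but it also carries a different urea aryl, so the two changes cannot be separated.

Compound 4 is therefore expected to land near or somewhat above compound 3, with an estimated step of a 1.3-fold higher number from compound 3 to compound 4 (0.12 log units; within the scatter), giving an estimate of 1100 nM within a range of 500 nM to 2500 nM.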

Compound 4, concentration for 50% growth inhibition: 576 nM
Estimate against measurement, compound 4: 1.9-fold (0.28 log units) above, and the stated range covers the measured number.
By their numbers in this assay, from the lowest: compounds 4, 3, 2 and 1 (each within the scatter of the next, the first and the last beyond it).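

In this assay, the pair with one change reads the oxygen on its own: a 1.5-fold lower number from compound 3 to compound 4 (0.16 log units; within the scatter) for methoxy to hydroxy lies within the scatter, so the two groups are not told apart here, and the hydroxy group alone does not go with the higher numbers seen earlier. The steps beyond the scatter fall on the urea aryl instead, with a 2.1-fold lower number from compound 2 to compound 4 (0.32 log units; beyond the scatter) for trifluoromethyl in place of chloro and a 3.1-fold lower number from compound 1 to compound 4 (0.50 log units; beyond the scatter) for chloro in place of hydrogen. No evidence is available on what lies behind any of these steps.

From the compounds shown here alone, the oxygen has been read only with hydrogen or methyl on it, so an ethyl group, a longer chain or a primary amine in place of the hydroxy group remains open. Going by these compounds, whether methoxy and hydroxy also stay within the scatter with 3,4-dichlorophenyl or 3-(trifluoromethyl)phenyl on the urea is also open.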